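Swapping Trifluoromethyl for Pyridin-2-yl on a Carbonyl Carbon

A few compounds are considered here, and "the series" means these few. Any claim that something is new, unique, unknown or untested is made for them only; others in the source may bear on it.

- compound 1 `O=C(C1CCN(C(=O)C(F)(F)F)CC1)N1N=CCC1c1ccccc1` gives 4.9
- compound 2 `CC(C)(C)C(=O)N1CCCCC1c1ccccc1` gives 6.7

In a physicochemical assay for lipophilicity, read by HPLC, measured as chromatographic lipophilicity, at pH 7.4 (a higher number here means a more lipophilic compound, a lower number a more polar compound), compound 1 (4.9) stands lowest of the two numbers, and compound 2 gives 6.7. That gap lies beyond the scatter. Compound 3 (`O=C(c1ccccn1)N1CCC(C(=O)N2N=CCC2c2ccccc2)CC1`) carries pyridin-2-yl in place of trifluoromethyl on a carbonyl carbon. For the measured compounds named here, no measured pair shows this change, so the expectation rests on the structures alone. In this assay a small downward step, slightly beyond the scatter, is expected (a number 0.40 log units lower from compound 1 to compound 3 (beyond the scatter)). For compound 3 the estimated value is 4.5 with an expected range from 3.9 to 5.1.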

Compound 3, distribution coefficient: 3.1
Compound 3: middle estimate off by 1.40 log units, on the high side; measured number outside the range, below it.
By their numbers in this assay, from the lowest: compound 3; then compound 1; then compound 2.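

In this assay the group on a carbonyl carbon bound to an amide-type nitrogen in a ring proves able to move the number by a large amount: pyridin-2-yl in place of trifluoromethyl gives a number 1.80 log units lower from compound 1 to compound 3 (beyond the scatter) in a single change. The step is downward although the entering group has more heavy atoms than the one that leaves. Nothing available explains the size of this step. Open, on these data alone, is how a methyl group or a cyclohexyl ring on the same carbonyl carbon would read, and whether the same swap on another core gives a step of similar size.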